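Aryl variation on the ring nitrogen: notes toward compound 3

The source may hold more compounds than are shown below. What is called first, only, known or untested is meant among the compounds shown, and "the series" means these compounds.

Measured so far in a functional assay on MCF7 cells (Homo sapiens) for antiproliferative activity, read by MTT assay, with a stated time of 48 h; a higher number here means a weaker inhibitor, a lower number a stronger inhibitor:
compound 1 `COc1cccc(-n2cc(COc3ccc(/C=C/C(C)=O)cc3OC)nn2)c1`: 1800 nM
compound 2 `COc1cc(/C=C/C(C)=O)ccc1OCc1cn(-c2ccccc2OC)nn1`: 29100 nM

For the measured compounds named here, compound 2 gives the highest of the two numbers; its nearest neighbour is compound 1, and the single step of a 16-fold higher number from compound 1 to compound 2 (1.21 log units; beyond the scatter) separates them. Compound 3 `COc1cc(/C=C/C(C)=O)ccc1OCc1cn(-c2ccc([N+](=O)[O-])cc2)nn1` carries 4-nitrophenyl in place of 2-methoxyphenyl on an aromatic nitrogen. Going by the values given here, no measured step exchanges an aryl group on the ring nitrogen for a nitro-bearing one, so the only bearing comes from a 16-fold higher number from compound 1 to compound 2 (1.21 log units; beyond the scatter), which shows that the aryl group on this nitrogen alone can move the number by a large amount. A shift of comparable size is therefore plausible for compound 3, and since compound 2 already stands at the high end of the two numbers, the more likely direction is downward, though the data do not fix the direction. The step expected from this reasoning is a 4.9-fold lower number from compound 2 to compound 3 (0.69 log units; beyond the scatter). Compound 3 is accordingly estimated at 6000 nM, with a range from 1200 nM to 30000 nM.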

Compound 3, half-maximal inhibitory concentration: > 100000 nM
Compound 3 ended at the assay's limit; the forecaster's own chance of this, stated with the estimate: 5%; middle value at least 16-fold (1.22 log units) away from the limit.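

In this assay compound 3 gives > 100000 nM, which is a limit of the assay and not a number: the limit of > 100000 nM in this assay, at which 1 of the 3 values shown sits.

Replacing the 2-methoxyphenyl group with 4-nitrophenyl on the aromatic nitrogen gives an at least 3.4-fold higher number from compound 2 to compound 3 (0.53 log units; beyond the scatter), and replacing the 3-methoxyphenyl group with the same 4-nitrophenyl group gives an at least 55-fold higher number from compound 1 to compound 3 (1.74 log units; beyond the scatter); both steps are minimum sizes only. Compound 1 and compound 2 showed that the number at this position responds to a change between two methoxyphenyl groups, while compound 3 shows that a change of aryl group alone, with the rest of the molecule unchanged, can carry the series to the limit of the assay.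

From the compounds shown here alone, how far compound 3 lies past that limit stays open, and so does whether the outcome belongs to the nitro group itself or to the loss of the methoxy group. An amine or a carboxylic acid in place of the nitro group on the same phenyl ring, or an unsubstituted phenyl group on this nitrogen, would fall outside the three aryl groups shown, and nothing here tells how the series would respond to them.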